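The source may report more compounds than this note shows. Statements on the series, on what has been measured and on what is new or still open speak of the compounds shown alone.

Of the compounds shown here, three built on one shared core have been read in a functional assay on MCF7 cells (Homo sapiens) for inhibition, read by sulforhodamine B assay; on this read-out lower numbers stand for stronger inhibition and higher numbers for weaker inhibition. Compound 1 `O=C1C(Nc2ccc(I)cc2)=CC(=O)c2c1nc1n2[C@H]2OC[C@@H](O)[C@H]2OC1`, with an iodo group, gives 3890 nM, and compound 2 `CCCc1ccc(NC2=CC(=O)c3nc4n(c3C2=O)[C@H]2OC[C@@H](O)[C@H]2OC4)cc1`, with a propyl chain, gives 4660 nM. These two values lie within the scatter of each other. Compound 3 `O=C1C(Nc2ccccc2)=CC(=O)c2c1nc1n2[C@H]2OC[C@@H](O)[C@H]2OC1`, with a plain anilino group, gives > 4000 nM, which is a limit and not a number. Its exact place on the scale is therefore unknown.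

Compound 4 `CCc1ccc(NC2=CC(=O)c3c(nc4n3[C@H]3OC[C@@H](O)[C@H]3OC4)C2=O)cc1` has ethyl in place of hydrogen on an aromatic carbon of compound 3: ethyl in place of hydrogen on an aromatic carbon. Among the measured compounds shown here, only one measured step changes a group on that aromatic ring, an at least 1.0-fold higher number from compound 1 to compound 3 (0.01 log units; that floor lies within the scatter), so swapping the iodo group for hydrogen shows no change beyond the scatter. With that step, and with compound 2 at 4660 nM carrying a chain one name longer than ethyl, no shift beyond the scatter is expected in this assay. The expected size of the change is a step that the limit leaves unreadable from compound 3 to compound 4. For compound 4 the estimate is 4500 nM, with an expected range from 2500 nM to 9000 nM.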

Compound 4, half-maximal inhibitory concentration: 8990 nM
Estimate against measurement, compound 4: 2.0-fold (0.30 log units) below; low and high end bracket the measured number.
By their numbers in this assay, from the lowest: compounds 1, 2 and 4 (each within the scatter of the next, the first and the last beyond it).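

In this assay, among the compounds shown here, ethyl in place of iodo on the aromatic carbon gives a 2.3-fold higher number from compound 1 to compound 4 (0.36 log units; beyond the scatter), the first step at this place on the ring that clears the scatter. The group here can therefore move the number, though only modestly. The change does not follow a clean line with chain groups, since compound 2 at 4660 nM, with its propyl chain, stays within the scatter of both compound 1 and compound 4.

Compound 3 holds only a limit, so the step from it to compound 4 cannot be read, and what ethyl does compared with plain hydrogen stays open: the limit of > 4000 nM in this assay, at which 1 of the 4 values shown sits.

On these data alone, how an amine, a carboxylic acid or a chain longer than propyl would read at this place in this assay also remains open.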